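The source may hold more compounds than are shown below. What is called first, only, known or untested is meant among the compounds shown, and "the series" means these compounds.

Measured in an ADME assay on microsomes from liver (Mus musculus) for metabolic stability, read by LC-MS, with a stated time of 10 min; on this read-out higher numbers stand for a more stable compound and lower numbers for a less stable compound:
compound 1 `CN(C[C@H]1Cc2c(cccc2N2CCN(C3CC3)CC2)CN1)[C@H]1CCCc2cccnc21` — 7%
compound 2 `CN1CCN(c2cccc3c2C[C@H](CN(C)[C@H]2CCCc4cccnc42)N(C)C3)CC1` — 41.7%
compound 3 `CN(C[C@H]1Cc2c(cccc2N2CCN(c3cccc(C(F)(F)F)c3)CC2)CN1)[C@H]1CCCc2cccnc21` — 72.3%

Compound 1 stands lowest of the three; compound 2 is nearest and compound 3 furthest, both beyond the scatter. Compound 4 `CN1CCN(c2cccc3c2C[C@H](CN(C)[C@H]2CCCc4cccnc42)NC3)CC1` differs from compound 1 by methyl in place of cyclopropyl on an amine nitrogen in a ring. Going by the values given here, the one measured step at this position, a number 65.3 percentage points higher from compound 1 to compound 3 (beyond the scatter), is large and upward. Among the compounds with values here, compound 2 also carries 4-methylpiperazin-1-yl but differs from compound 1 in a second place as well, so its number only shows that such a compound can sit well above compound 1; no single step links it to compound 1 or compound 4. An upward step is therefore expected, smaller than that to compound 3. Compound 4 is estimated at 25% (range 8% to 50%), an expected step of a number 18 percentage points higher from compound 1 to compound 4 (beyond the scatter).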

Compound 4, percent of the compound remaining: 17%
For compound 4 the middle estimate is 8 percentage points above the measured one; measured number inside the range.
By their numbers in this assay, from the lowest: compounds 1 and 4 (each within the scatter of the next); then compound 2; then compound 3.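

In this assay, methyl in place of cyclopropyl gives a number 10 percentage points higher from compound 1 to compound 4 (within the scatter) and so does not separate these two groups on the amine nitrogen. The large gain at this position stays with the aryl group, as methyl in place of 3-(trifluoromethyl)phenyl gives a number 55.3 percentage points lower from compound 3 to compound 4 (beyond the scatter) here. A second site also matters, since hydrogen in place of methyl on an amine nitrogen in a ring gives a number 24.7 percentage points lower from compound 2 to compound 4 (beyond the scatter) in this series.

From the compounds shown here alone, whether unsubstituted phenyl or an ethyl chain on the piperazine nitrogen would keep any of that gain remains open. No available evidence bears on what lies behind these differences.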